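Aryl swap on the shared core: compound 3 to compound 4

A few compounds are considered here, and "the series" means these few. Any claim that something is new, unique, unknown or untested is made for them only; others in the source may bear on it.

Measured so far:
compound 1 `c1cn2cc(-c3ccsc3)nc(-c3ccc4ncn(C5CCCCC5)c4c3)c2n1` — 5.56%
compound 2 `CC(=O)c1ccc(-c2cn3ccnc3c(-c3ccc4ncn(C5CCCCC5)c4c3)n2)cc1` — 6.34%
compound 3 `Brc1ccc(-c2cn3ccnc3c(-c3ccc4ncn(C5CCCCC5)c4c3)n2)cc1` — 24.5%

In a functional assay on Hs-578T cells (Homo sapiens) for inhibition, read by sulforhodamine B assay, with a stated time of 48 h, tested at 10 uM (on this read-out higher numbers stand for more inhibition at the one concentration tested (going by the name of the read-out) and lower numbers for less inhibition), compound 3 stands highest of the three numbers: a number 18.9 percentage points higher from compound 1 to compound 3 (beyond the scatter) and a number 18.2 percentage points higher from compound 2 to compound 3 (beyond the scatter), each beyond the scatter, while compound 1 and compound 2 lie within the scatter of one another.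

Compound 4 `Fc1ccccc1-c1cn2ccnc2c(-c2ccc3ncn(C4CCCCC4)c3c2)n1` differs from compound 3 in one place: 2-fluorophenyl in place of 4-bromophenyl on an aromatic carbon. For the measured compounds named here, no measured step exchanges one halogen for another or moves a substituent around the phenyl ring, so no step bears directly on this change. The two steps ending at compound 3 show only that 4-bromophenyl gave more inhibition than thiophen-3-yl or 4-acetylphenyl. Part of that gain is expected to be lost, a step of a number 12.5 percentage points lower from compound 3 to compound 4 (beyond the scatter). Compound 4 is estimated at 12%, with a range of 0% to 28%.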

Compound 4, a percentage reported as inhibition, at one concentration (the size of the read-out at that concentration, not a potency): 5.26%
Beside the measured number, compound 4's estimate is 6.7 percentage points above it; the range from low to high includes it.
By their numbers in this assay, from the lowest: compounds 4, 1 and 2 (each within the scatter of the next); then compound 3.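

At this place on the shared core, 2-fluorophenyl does not hold the number seen with 4-bromophenyl, with a step of a number 19.2 percentage points lower from compound 3 to compound 4 (beyond the scatter) and with the other two groups no different, at a number 1.1 percentage points lower from compound 2 to compound 4 (within the scatter) and a number 0.3 percentage points lower from compound 1 to compound 4 (within the scatter) in turn. A phenyl ring alone therefore does not bring the higher number, and compound 3 remains the only one of the four apart from the rest. Nothing available accounts for this step.

The halogen and its place on the phenyl ring remain unseparated, since compound 3 and compound 4 differ in both. From the compounds shown here alone, how an amine or a carboxylic acid on that ring would read remains open.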